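Swapping the aniline substituent in a weak antiproliferative series

The compounds below may be only part of what the source reports. "The series", "measured", "known", "first", "only" and "open" are said of these compounds alone.

Going by the values given here, compound 2 `CC(C)Nc1nc(Nc2ccc(N3CCN(C)CC3)cc2)ncc1/N=C/c1ccccc1` is one of two compounds measured in a functional assay on HT-29 cells (Homo sapiens) for antiproliferative activity, read by MTT assay; a higher number here means a weaker inhibitor, a lower number a stronger inhibitor. In this assay compound 2 gives 12100 nM, the highest of the two numbers. Among the compounds with values here, its closest relative, compound 1 `CCOC(=O)/C=N/c1cnc(Nc2ccc(N3CCN(C)CC3)cc2)nc1NC(C)C`, gives 7590 nM in this assay, and the one measured step, a 1.6-fold higher number from compound 1 to compound 2 (0.20 log units; within the scatter), stays within the scatter, so the two compounds cannot be ranked against each other.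

Compound 3 `CC(C)Nc1nc(Nc2ccc(S(N)(=O)=O)cc2)ncc1/N=C/c1ccccc1` differs from compound 2 in a single place: sulfamoyl in place of 4-methylpiperazin-1-yl on an aromatic carbon. Within the data shown here, no measured step involves this position or either of these two groups; the only known step concerns the group on the carbon with a double bond to nitrogen, and it was flat. There is therefore no direct basis in the data for the size or direction of the step to compound 3, and any expectation rests on the change itself.

Compound 3 is expected to give a somewhat lower number than compound 2, an estimated step of a 2.0-fold lower number from compound 2 to compound 3 (0.30 log units; within the scatter), though the uncertainty is wide. The estimate for compound 3 in this assay is 6000 nM, within a range from 1500 nM to 25000 nM.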

Compound 3, half-maximal inhibitory concentration: 98200 nM
Estimate against measurement, compound 3: 16-fold (1.21 log units) below, and the stated range ends below it.
By their numbers in this assay, from the lowest: compounds 1 and 2 (each within the scatter of the next); then compound 3.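

Going by these compounds alone, the position on the six-membered aromatic ring of carbon only, para to a large group, turns out to respond in this assay: sulfamoyl in place of 4-methylpiperazin-1-yl gives an 8.1-fold higher number from compound 2 to compound 3 (0.91 log units; beyond the scatter), a modest step beyond the scatter, whereas the only earlier step, at the carbon with a double bond to nitrogen, stayed within it. The change is also a composite one, as a group of 7 heavy atoms with one six-membered non-aromatic ring and no hydrogen-bond donor gives way to a group of 4 heavy atoms with no ring and 1 hydrogen-bond donor. Nothing measured here accounts for the step, which therefore records only its size and direction.

With only these two groups at this position, the ring, the size of the group and the hydrogen-bond donor cannot be separated from one another. Going by these compounds, how a morpholine ring, an unsubstituted piperazine, a dimethylamino group or a carboxylic acid would read at this place remains open, as does whether the step would hold with ethoxycarbonyl in place of phenyl on the carbon with a double bond to nitrogen.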